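This account rests on a few compounds, and the source may have more. Where it says the series, first, only, none or still open, it means among the compounds named here.

Measured compounds:
Compound 1 `CCc1ccc(-c2cn3ccnc3c(-c3ccc4ncn(C5CCCCC5)c4c3)n2)cc1` gives 1.66 in a physicochemical assay for lipophilicity, using the shake flask method, in phosphate buffer, measured as octanol-water partition, with a stated time of 85 min, at pH 7.4; a lower number here means a more polar compound, a higher number a more lipophilic compound.
Compound 2 `Fc1ccccc1-c1cn2ccnc2c(-c2ccc3ncn(C4CCCCC4)c3c2)n1` gives 1.95 in this assay.

Among the compounds with values here, compound 1 stands lowest of the two numbers measured so far, with compound 2 nearest; the step of a number 0.29 log units higher from compound 1 to compound 2 (within the scatter) lies within the scatter, so the two values cannot be told apart. Compound 3 `CCc1ccc(-c2cn3ccnc3c(-c3ccc4ncn(Cc5ccccc5)c4c3)n2)cc1` has not yet been measured. It differs from compound 1 in one place: benzyl in place of cyclohexyl on an aromatic nitrogen. Within the data shown here, no measured step touches that place. Among the measured compounds shown here, the only step on record, from compound 1 to compound 2, exchanges one group on an aromatic carbon and was small, so it gives no guide to a change on the aromatic nitrogen. What remains is the difference in the groups themselves, as counted: a six-membered non-aromatic ring of carbon only leaves and a seven-atom benzyl with a six-membered aromatic ring enters. On that basis compound 3 is expected to come out somewhat lower than compound 1, a step of a number 0.31 log units lower from compound 1 to compound 3 (beyond the scatter), though the change could also fall within the scatter. The estimate for compound 3 in this assay is 1.35, with a range from 0.9 to 1.8.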

Compound 3, partition coefficient: 1.96
Estimate against measurement, compound 3: 0.61 log units below, and the stated range ends below it.
By their numbers in this assay, from the lowest: compounds 1, 2 and 3 (each within the scatter of the next).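

Within the data shown here, the aromatic nitrogen of the five-membered aromatic ring, which no earlier step touched, now has a reading of its own in this assay: benzyl in place of cyclohexyl gives a number 0.30 log units higher from compound 1 to compound 3 (within the scatter). At this place, then, a six-membered aromatic ring of carbon only, carried on benzyl, and a six-membered non-aromatic ring of carbon only could not be told apart by this measurement, with the 4-ethylphenyl group and the rest of the core of compound 1 held the same. No separate measurement bears on this result, and the data offer no account of it.

The compounds shown leave open whether a group of another kind on the same aromatic nitrogen, such as a chain ending in an amine or a carboxylic acid, would give a step beyond the scatter. They also do not show whether benzyl in place of cyclohexyl reads the same when the aromatic carbon carries the 2-fluorophenyl group of compound 2 rather than 4-ethylphenyl.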